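Nitro in place of cyano on compound 3

The source may hold more compounds than are shown below. What is called first, only, known or untested is meant among the compounds shown, and "the series" means these compounds.

Within the data shown here, in a functional assay on U-373MG ATCC cells (Homo sapiens) for inhibition, read by MTT assay, with a stated time of 72 h (on this read-out lower numbers stand for stronger inhibition and higher numbers for weaker inhibition), compound 3 (`CC1(C)CC(NC(=S)Nc2cccc(C#N)c2)c2cc(F)ccc2O1`) gives 30000 nM as the highest of the three numbers so far. Compound 1 (`CC1(C)CC(NC(=S)Nc2cccc(C#N)c2)c2cc(Br)ccc2O1`) gives 6000 nM and compound 2 (`CC1(C)CC(NC(=S)Nc2ccc(C#N)cc2)c2cc(F)ccc2O1`) gives 11000 nM on the same read-out. Compound 4 (`CC1(C)CC(NC(=S)Nc2cccc([N+](=O)[O-])c2)c2cc(F)ccc2O1`) carries nitro in place of cyano on an aromatic carbon and is otherwise the same as compound 3.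

Among the measured compounds shown here, no measured step exchanges this group. For the measured compounds named here, the only guides are a 5.0-fold higher number from compound 1 to compound 3 (0.70 log units; beyond the scatter) for fluoro in place of bromo and a 2.7-fold higher number from compound 2 to compound 3 (0.44 log units; beyond the scatter) for 3-cyanophenyl in place of 4-cyanophenyl. Both are modest and beyond the scatter, yet they bear on the new change only as a measure of size. A step no larger than these is therefore expected in this assay and most likely none beyond the scatter. With compound 3 at 30000 nM as the top number, a slight lean to a lower number is expected. The expected change is a 1.5-fold lower number from compound 3 to compound 4 (0.18 log units; within the scatter) and stays within the scatter. The estimate for compound 4 is 20000 nM with an expected range from 7000 nM to 60000 nM on this read-out.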

Compound 4, half-maximal inhibitory concentration: 6000 nM
Beside the measured number, compound 4's estimate is 3.3-fold (0.52 log units) above it; measured number outside the range, below it.
By their numbers in this assay, from the lowest: compounds 1, 4 and 2 (each within the scatter of the next); then compound 3.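

The substituent on this aromatic carbon, meta to a large group, matters in this assay: nitro in place of cyano gives a 5.0-fold lower number from compound 3 to compound 4 (0.70 log units; beyond the scatter). Among these compounds, until now, the cyano group had only been moved, so this is the first exchange of the group itself, and its size matches that of the halogen exchange, a 5.0-fold higher number from compound 1 to compound 3 (0.70 log units; beyond the scatter). Nothing available explains why the nitro compound gives the lower number.

On these data alone, it remains open whether the nitro-for-cyano step carries over to the bromo series or to the 4-cyanophenyl arrangement, since the step has been read only on the fluoro compound with the 3-cyanophenyl group. As far as these compounds go, how an amine or a carboxylic acid on this same aromatic carbon would read in this cell assay also stays open.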